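Adding a Methoxycarbonyl to Compound 1

The compounds below may be only part of what the source reports. "The series", "measured", "known", "first", "only" and "open" are said of these compounds alone.

Measured compounds:
Compound 1 `C[C@H]1COC2(CCN(c3nc(=O)c4cc(C(F)(F)F)cc([N+](=O)[O-])c4s3)CC2)O1`: 11000 nM
Compound 2 `CN(C(=O)CN1CCN(c2nc(=O)c3cc(C(F)(F)F)cc([N+](=O)[O-])c3s2)CC1)c1ccccc1`: 30000 nM

Both compounds were tested in an ADME assay on K562 cells (Homo sapiens) for antiproliferative activity, with a stated time of 72 h; a lower number here means a stronger inhibitor of growth, a higher number a weaker inhibitor of growth. In this assay compound 1 gives 11000 nM, and compound 2 gives 30000 nM. Of these two numbers, compound 1 has the lower one; the gap to compound 2 lies beyond the usual scatter of repeated measurements, so compound 1 is the stronger growth inhibitor of the pair. For the measured compounds named here, no single-point step between compound 1 and compound 2 has been worked out, since they differ in more than one place.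

Compound 3 `COC(=O)C1CN(c2nc(=O)c3cc(C(F)(F)F)cc([N+](=O)[O-])c3s2)CCC12OC[C@H](C)O2` has not yet been measured. It differs from compound 1 in one place: methoxycarbonyl in place of hydrogen on a saturated ring carbon. Going by the values given here, no measured pair shows what such a change does here, so there is no basis for expecting a shift in either direction. The step of a 1.1-fold higher number from compound 1 to compound 3 (0.04 log units; within the scatter) is therefore expected to stay within the scatter, with a wide range to allow for surprises. Compound 3 is estimated at 12000 nM, between 4000 nM and 40000 nM.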

Compound 3, concentration for 50% growth inhibition: 22000 nM
Compound 3: the middle estimate sits 1.8-fold (0.26 log units) below what was measured; the range from low to high includes it.
By their numbers in this assay, from the lowest: compounds 1, 3 and 2 (each within the scatter of the next, the first and the last beyond it).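

For the compounds shown here, compound 1 and compound 3 form the first pair in this assay that differs in one place only, and the step reads a 2.0-fold higher number from compound 1 to compound 3 (0.30 log units; within the scatter) for methoxycarbonyl in place of hydrogen on a saturated ring carbon. This ring carbon, two ring bonds from the ring nitrogen, can therefore carry a group of 4 heavy atoms with no shift in growth inhibition that can be told apart from the ordinary spread of repeated measurements, so neither compound can be called the stronger of this pair. Nothing available bears on why the step has this size.

From the compounds shown here alone, one group at one position cannot show how this ring carbon responds to substitution in general, and it remains open whether a carboxylic acid, a primary amide or a plain methyl here would also stay within the scatter. The pair also leaves open whether methoxycarbonyl would give a similar step on a core carrying a different group in place of the ring system of compound 1.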